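What a large sulfonyl group may do to potency

The compounds below may be only part of what the source reports. "The series", "measured", "known", "first", "only" and "open" are said of these compounds alone.

In a functional assay on KB cells (Homo sapiens) for cytotoxicity, read by MTT assay, with a stated time of 3 days (a higher number here means a weaker inhibitor, a lower number a stronger inhibitor), compound 3 `N#Cc1c(-c2ccccc2)nc(SCc2nc3ccccc3[nH]2)nc1N1CCNCC1` gives 2.87 nM, and compound 1 `N#Cc1c(Nc2ccccc2)nc(SCc2nc3ccccc3[nH]2)nc1-c1ccccc1` gives 2.9 nM, so the two sit level within the scatter. Compound 2 `N#Cc1c(Nc2nccs2)nc(SCc2nc3ccccc3[nH]2)nc1-c1ccccc1` gives 14.7 nM, a clearly higher number. Compound 3 therefore shares the low, stronger end of this small set with compound 1.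

Compound 4 `Cc1ccc(S(=O)(=O)N2CCN(c3nc(SCc4nc5ccccc5[nH]4)nc(-c4ccccc4)c3C#N)CC2)cc1` differs from compound 3 at one place, an amine nitrogen in a ring: (4-methylphenyl)sulfonyl in place of hydrogen on an amine nitrogen in a ring.

Among the compounds with values here, no measured step changes this nitrogen, so the evidence is only indirect. Two steps swap the group on the aromatic carbon that carries this ring: a 1.0-fold lower number from compound 1 to compound 3 (0.00 log units; within the scatter) stays within the scatter, while a 5.1-fold lower number from compound 2 to compound 3 (0.71 log units; beyond the scatter) is modest. A third step, a 5.1-fold higher number from compound 1 to compound 2 (0.70 log units; beyond the scatter), is also modest. Changes near this part of compound 3 have so far moved the number only modestly, so a small rise is expected, a 2.1-fold higher number from compound 3 to compound 4 (0.32 log units; beyond the scatter), though this is uncertain. For compound 4 the estimated value is 6 nM, with an expected range of 1.2 nM to 30 nM.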

Compound 4, half-maximal inhibitory concentration: 3.28 nM
The estimate for compound 4 lay 1.8-fold (0.26 log units) above the measured number, within the range that was stated.
By their numbers in this assay, from the lowest: compounds 3, 1 and 4 (each within the scatter of the next); then compound 2.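

The first direct test of this nitrogen in this assay gives a 1.1-fold higher number from compound 3 to compound 4 (0.06 log units; within the scatter). Putting (4-methylphenyl)sulfonyl, with its 10 heavy atoms and six-membered aromatic ring, in place of a single hydrogen therefore leaves compound 3 and compound 4 level, so this amine nitrogen in a ring can carry a large group without a measurable loss in this cell assay. No measurement shown here bears on why the two sit level.

Going by these compounds, this is one group on one core, so it remains open whether the result extends to other groups on this nitrogen, such as methylsulfonyl, acetyl or benzoyl. A plain methyl or a chain ending in a carboxylic acid could also behave differently there.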